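Trifluoromethoxy on the aryl piperazine of compound 3

The source may report more compounds than this note shows. Statements on the series, on what has been measured and on what is new or still open speak of the compounds shown alone.

Measured compounds:
Compound 1 `COc1ccccc1N1CCN(CCCNc2ncccc2C(=O)C2CC2)CC1`: 0.501 nM
Compound 2 `COc1ccccc1N1CCN(CCCNc2ccccc2C(=O)c2ccccc2)CC1`: 31.6 nM
Compound 3 `CN(C)C(=O)c1cccnc1NCCCN1CCN(c2ccccc2)CC1`: 6.31 nM

In a functional assay for antagonist activity at Alpha-1A adrenergic receptor (Oryctolagus cuniculus) (a lower number here means tighter binding, a higher number weaker binding), compound 1 gives 0.501 nM, and compound 2 gives 31.6 nM. Compound 3 gives 6.31 nM in this assay, which places it second highest among the three numbers: its nearest neighbour is compound 2, whose number is higher by a margin beyond the scatter, and the furthest is compound 1, whose number is lower by a margin also beyond the scatter. Among the compounds with values here, compounds 1 and 2 differ from compound 3 in more than one place, so no single step between measured compounds is available.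

Compound 4 `CN(C)C(=O)c1cccnc1NCCCN1CCN(c2ccccc2OC(F)(F)F)CC1` differs from compound 3 in one place: trifluoromethoxy in place of hydrogen on an aromatic carbon. Within the data shown here, nothing among the measured compounds isolates the effect of this group at this position; the two compounds carrying an alkoxy group there, compound 1 and compound 2, also carry different groups elsewhere. The step from compound 3 to compound 4 is therefore expected to be small, most likely a modest move toward a lower number, a 1.6-fold lower number from compound 3 to compound 4 (0.20 log units; within the scatter), though a result within the scatter would not surprise. For compound 4 the estimated value in this assay is 4 nM, with a range from 1.5 nM to 12 nM.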

Compound 4, dissociation constant: 3.16 nM
Compound 4: the middle estimate sits 1.3-fold (0.10 log units) above what was measured; low and high end bracket the measured number.
By their numbers in this assay, from the lowest: compound 1; then compounds 4 and 3 (each within the scatter of the next); then compound 2.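

In this assay, trifluoromethoxy in place of hydrogen on an aromatic carbon, ortho to a large group, gives a 2.0-fold lower number from compound 3 to compound 4 (0.30 log units; within the scatter). Within the data shown here, this is the first comparison that isolates a single place, and it shows that this carbon of the six-membered aromatic ring can carry a substituent of 5 heavy atoms, including 3 fluorine, with no change in the number beyond the usual scatter of the measurement. No accompanying measurement is available to account for this result.

The compounds shown leave open how other groups would read at this same position, such as an amine, a carboxylic acid or a single chlorine, and whether a methoxy group there, as carried by compound 1 and compound 2, would differ from trifluoromethoxy on an otherwise identical compound. They also leave open whether the tolerance seen with the dimethyl amide of compound 3 and compound 4 would carry over to the cyclopropyl ketone of compound 1, which differs from both in more than one place.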